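Swapping the aryl group on the sulfonamide of compound 1

This account rests on a few compounds, and the source may have more. Where it says the series, first, only, none or still open, it means among the compounds named here.

Measured compounds:
- compound 1, `CCOC(=O)c1oc2ccc(NS(=O)(=O)c3cccc(C)c3)cc2c1C`: 25300 nM
- compound 2, `CCOC(=O)c1oc2ccc(NS(=O)(=O)c3ccccc3[N+](=O)[O-])cc2c1C`: 96900 nM
- compound 3, `CCOC(=O)c1oc2ccc(NS(=O)(=O)c3ccc(OC)c(OC)c3)cc2c1C`: 20500 nM

These three share one core and differ only in the aromatic group attached to the sulfonyl sulfur. In a functional assay on MDA-MB-468 cells (Homo sapiens) for antiproliferative activity, read by MTT assay, with a stated time of 72 h (on this read-out lower numbers stand for stronger inhibition and higher numbers for weaker inhibition), compound 1 stands second highest of the three numbers. Compound 3 sits closest, and its number lies within the scatter of that of compound 1. For the measured compounds named here, compound 2 lies furthest, as the one measured step shows: a 3.8-fold higher number from compound 1 to compound 2 (0.58 log units; beyond the scatter).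

Compound 4, `CCOC(=O)c1oc2ccc(NS(=O)(=O)c3cccs3)cc2c1C`, has not yet been measured. Its change from compound 1 is thiophen-2-yl in place of 3-methylphenyl on a sulfonyl sulfur. Going by the values given here, no measured step places a thiophen-2-yl on the sulfonyl sulfur, so the only guidance is that the move to 2-nitrophenyl gave a modest rise while the move to 3,4-dimethoxyphenyl, seen in compound 3, stayed within the scatter. The change in compound 4 is therefore expected to give a step that stays within the scatter or is at most small: a 1.2-fold higher number from compound 1 to compound 4 (0.07 log units; within the scatter). Compound 4 is thus estimated at 30000 nM, with a likely range from 12000 nM to 75000 nM.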

Compound 4, half-maximal inhibitory concentration: 34300 nM
Compound 4: middle estimate off by 1.1-fold (0.06 log units), on the low side, and the stated range covers the measured number.
By their numbers in this assay, from the lowest: compounds 3, 1 and 4 (each within the scatter of the next); then compound 2.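

In this assay the sulfonyl sulfur accepts a five-membered aromatic ring containing sulfur in place of the six-membered carbon ring of compound 1, and the step stays within the scatter (a 1.4-fold higher number from compound 1 to compound 4 (0.13 log units; within the scatter)). This shows that a benzene-type ring is not needed at this position for a number in this range, at least for thiophen-2-yl. Replacing 2-nitrophenyl with thiophen-2-yl gives a modest step beyond the scatter (a 2.8-fold lower number from compound 2 to compound 4 (0.45 log units; beyond the scatter)), so the weak result of compound 2 does not carry over to this smaller ring.

No measurement shown here explains these steps. As far as these compounds go, it remains open whether a sulfonyl sulfur carrying a simple methyl or a saturated cyclohexyl group, or an aryl ring bearing an amine or a carboxylic acid, would stay in this range.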